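Acetyl for Methoxy on the Outer Ring: Compound 4

The source may hold more compounds than are shown below. What is called first, only, known or untested is meant among the compounds shown, and "the series" means these compounds.

Three measured compounds share one core and differ only in the group carried on the outer phenyl ring. Compound 1 `O=C(CCc1cccc2c1B(O)OC2)Nc1cccc(-c2ccccc2)c1` gives 220 nM in a functional assay on MDA-MB-231 cells (Homo sapiens) for antiproliferative activity, read by MTT assay, with a stated time of 72 h; a lower number here means a stronger inhibitor, a higher number a weaker inhibitor. Compound 2 `COc1ccc(-c2cccc(NC(=O)CCc3cccc4c3B(O)OC4)c2)cc1`, which carries a methoxy group, gives 88 nM in this assay, the lowest of the three numbers. Compound 3 `O=C(CCc1cccc2c1B(O)OC2)Nc1cccc(-c2ccc(OC(F)(F)F)cc2)c1`, which carries a trifluoromethoxy group, gives 640 nM in this assay. The steps between them are a 2.5-fold lower number from compound 1 to compound 2 (0.40 log units; beyond the scatter), a 2.9-fold higher number from compound 1 to compound 3 (0.46 log units; beyond the scatter) and a 7.3-fold higher number from compound 2 to compound 3 (0.86 log units; beyond the scatter), so a change on this ring can shift the number in either direction, each time by a modest amount beyond the scatter.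

Compound 4 `CC(=O)c1cccc(-c2cccc(NC(=O)CCc3cccc4c3B(O)OC4)c2)c1` has not yet been measured. (3-acetylphenyl in place of 4-methoxyphenyl on an aromatic carbon). Within the data shown here, no measured step involves an acetyl group, and none places a group meta to a large group, so the three steps bear on the change only loosely. The methoxy group is removed in compound 4, and because a 2.5-fold lower number from compound 1 to compound 2 (0.40 log units; beyond the scatter) showed that adding it lowered the number, compound 4 is expected to move back toward compound 1, with an expected step of a 2.8-fold higher number from compound 2 to compound 4 (0.45 log units; beyond the scatter). The estimate for compound 4 in this assay is 250 nM, within a range of 80 nM to 800 nM.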

Compound 4, half-maximal inhibitory concentration: 52 nM
Compound 4: middle estimate off by 4.8-fold (0.68 log units), on the high side; the measured number lies below the stated range.
By their numbers in this assay, from the lowest: compounds 4 and 2 (each within the scatter of the next); then compound 1; then compound 3.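

In this assay the 3-acetylphenyl group stands level with the 4-methoxyphenyl group, with a 1.7-fold lower number from compound 2 to compound 4 (0.23 log units; within the scatter) and so no return toward compound 1 once the methoxy group has gone. Measured against the plain outer ring of compound 1, acetyl gives a 4.2-fold lower number from compound 1 to compound 4 (0.63 log units; beyond the scatter) and shows that a group meta to a large group can also lower the number, so compounds 2 and 4 now both sit lower than compound 1 with different groups in different places, while compound 3 goes against any rule that a group on this ring lowers the number. Nothing shown here accounts for the size or direction of these shifts.

The compounds shown leave group and place tied together, so it remains open whether acetyl would hold its number in the place the methoxy group occupies in compound 2, and whether methoxy would do the same in the place acetyl occupies in compound 4. As far as these compounds go, it is also open how far this place accepts other groups, such as an amine, a carboxylic acid or a longer chain ketone in place of the acetyl group.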